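Dropping the Amino Group From a Weakly Cytotoxic Core

The compounds below may be only part of what the source reports. "The series", "measured", "known", "first", "only" and "open" are said of these compounds alone.

Compound 1 `Nc1nc(Cl)c2ncn(Cc3ccccc3CCl)c2n1` is only weakly cytotoxic. In a functional assay on HCT-116 cells (Homo sapiens) for cytotoxicity, read by sulforhodamine B assay, with a stated time of 48 h (a lower number here means that less compound is tolerated, a higher number that more compound is tolerated), compound 1 gives a limit rather than a number, > 100000 nM, and so stands at the limit of > 100000 nM in this assay, at which 1 of the 2 values shown sits. Compound 2 `Nc1nc(Cl)c2ncn(Cc3cccc(CCl)c3)c2n1`, a related compound, gives 75900 nM in this assay. Compound 3 `ClCc1ccccc1Cn1cnc2c(Cl)ncnc21` differs from compound 1 by hydrogen in place of amino on an aromatic carbon. For the measured compounds named here, no measured pair shows what this change does, so the step from compound 1 to compound 3 in this assay is expected to be small, if any beyond the scatter. Compound 3 is therefore expected to give about 100000 nM, within 30000 nM to 300000 nM. The expected step is a number no higher from compound 1 to compound 3 (the limit leaves the size open).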

Compound 3, concentration lethal to 50% of the cells: 7080 nM
Estimate against measurement, compound 3: 14-fold (1.15 log units) above; measured number below the stated range.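

In this assay, the change of hydrogen in place of amino on an aromatic carbon, between two ring nitrogen atoms, gives an at least 14-fold lower number from compound 1 to compound 3 (1.14 log units; beyond the scatter). For the compounds shown here, compound 1 and compound 2 both carry the amino group, so only this step reveals that the group's presence at this position strongly affects how much compound the cells tolerate. Compound 1 gives only a limit, so the true size of the step stays open: the limit of > 100000 nM in this assay, at which 1 of the 3 values shown sits.

On these data alone, whether a methyl or methoxy group at this position would behave like hydrogen remains open. So does whether the same change would give a similar step on compound 2.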